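The compounds below may be only part of what the source reports. "The series", "measured", "known", "first", "only" and "open" are said of these compounds alone.

Three compounds share one core and differ only in the group on the urea end. In a functional assay on MDA-MB-231 cells (Homo sapiens) for cytotoxicity, read by MTT assay, with a stated time of 72 h (on this read-out higher numbers stand for weaker inhibition and lower numbers for stronger inhibition), compound 1 `CN(C)CCNc1nc(-c2ccc(NC(=O)Nc3ccc(F)cc3)cc2)nc2ccsc12` gives 540 nM, compound 2 `CN(C)CCNc1nc(-c2ccc(NC(=O)Nc3ccccc3F)cc2)nc2ccsc12` gives 600 nM, and compound 3 `CN(C)CCNc1nc(-c2ccc(NC(=O)Nc3ccc(Cl)cc3)cc2)nc2ccsc12` gives 310 nM. Compound 2 sits at the upper end of these three numbers, yet both gaps are within the scatter: a 1.1-fold higher number from compound 1 to compound 2 (0.05 log units; within the scatter) and a 1.9-fold lower number from compound 2 to compound 3 (0.29 log units; within the scatter). Compound 4 `CCN(CC)CCCNc1nc(-c2ccc(NC(=O)Nc3ccccc3F)cc2)nc2ccsc12` changes a different part of the molecule: (diethylamino)methyl in place of dimethylamino on a saturated chain carbon, two bonds along the chain from a nitrogen on an aromatic ring. Going by the values given here, no measured step touches this chain, so nothing here points in either direction. The expectation is therefore no change at the digits printed from compound 2 to compound 4 (within the scatter), that is, no step beyond the scatter. Compound 4 is expected to give about 600 nM in this assay, with a range from 250 nM to 1500 nM.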

Compound 4, half-maximal inhibitory concentration: 860 nM
Compound 4: middle estimate off by 1.4-fold (0.16 log units), on the low side; measured number inside the range.
By their numbers in this assay, from the lowest: compounds 3, 1, 2 and 4 (each within the scatter of the next, the first and the last beyond it).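

Going by these compounds alone, the side chain, which no earlier step touched, goes from 2-(dimethylamino)ethyl to 3-(diethylamino)propyl with the urea end held as in compound 2, and this gives a 1.4-fold higher number from compound 2 to compound 4 (0.16 log units; within the scatter) in this assay. In this single pair, then, the larger chain leaves the number within the scatter. Nothing available bears on why this is so.

Chain length and the groups on the end nitrogen change together here, so a 3-(dimethylamino)propyl or 2-(diethylamino)ethyl chain would be needed to separate them. On these data alone, a morpholine or a primary amine at the chain end also remains open.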